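This account rests on a few compounds, and the source may have more. Where it says the series, first, only, none or still open, it means among the compounds named here.

Measured compounds in an ADME assay on MDBK cells (Bos taurus) for cytotoxicity, read by MTT assay, with a stated time of 96 h; a higher number here means that more compound is tolerated, a lower number that less compound is tolerated:

Compound 1, `COc1ccc(-c2nc3cc(Cl)c(Cl)cc3[nH]2)cc1`, gives 2500 nM.
Compound 2, `O=[N+]([O-])c1ccc(-c2nc3cc(C(F)(F)F)ccc3[nH]2)cc1`, gives 6000 nM.
Compound 3, `O=[N+]([O-])c1ccc(-c2nc3cc(C(F)(F)F)ccc3[nH]2)c([N+](=O)[O-])c1`, gives 16000 nM.

Compound 1 has the lowest of the three numbers in this assay; compound 2 stands nearest to it and compound 3 furthest. The difference between the core of compound 1 and the core of compound 2 is not broken down here.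

Within the pair that shares a core, the one counted change is nitro in place of hydrogen on an aromatic carbon. This change gave a 2.7-fold higher number from compound 2 to compound 3 (0.43 log units; beyond the scatter).

Compound 4, `COc1ccc(-c2nc3cc(Cl)c(Cl)cc3[nH]2)c([N+](=O)[O-])c1`, is not yet measured in this assay. It differs from compound 1 by nitro in place of hydrogen on an aromatic carbon. Among the compounds with values here, the change is of the same kind as the one from compound 2 to compound 3, not the same: in the measured pair the entering nitro stands meta to a nitro group, whereas in compound 4 it stands meta to a methoxy group, and the cores differ as noted. Within the data shown here, only this single measured pair shows the change, so the expectation rests on one step.

Among the measured compounds shown here, for compound 4 in this assay a step of about a 2.4-fold higher number from compound 1 to compound 4 (0.38 log units; beyond the scatter) is expected, because a 2.7-fold higher number from compound 2 to compound 3 (0.43 log units; beyond the scatter) is the only measured precedent for the change. Compound 4 is accordingly estimated at 6000 nM, within the range 2500 nM to 15000 nM.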

Compound 4, half-maximal cytotoxic concentration: 28000 nM
The estimate for compound 4 lay 4.7-fold (0.67 log units) below the measured number, and the stated range ends below it.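

In this assay, nitro in place of hydrogen on an aromatic carbon gave an 11-fold higher number from compound 1 to compound 4 (1.05 log units; beyond the scatter), so the change raised the number on both cores, but the size of the step did not carry over from one core to the other: the same change on two cores in this assay, a 2.7-fold higher number (0.43 log units; beyond the scatter) from compound 2 to compound 3 and an 11-fold higher number (1.05 log units; beyond the scatter) from compound 1 to compound 4, 4.2-fold (0.62 log units) apart, beyond the scatter of two such steps

For this series, the direction of the step held in both available pairs, whereas a step size read from one core proved a poor guide to the size on the other. Two pairs show no general rule, and they do not separate what the core contributes from what the other substituents contribute, since compound 1 and compound 2 differ in more than one place; no cause for the gap can be assigned from these data.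

Going by these compounds, it remains open whether the larger step on the core of compound 1 is specific to nitro or would also appear with another group on the same aromatic carbon, such as an amine or a carboxylic acid. On these data alone, it is also open how the step would behave if the methoxy group of compound 1 were replaced by a longer chain, with the rest of the core unchanged.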